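This account rests on a few compounds, and the source may have more. Where it says the series, first, only, none or still open, it means among the compounds named here.

Compound 1 `CCCCCCCCCCCCCCCCCC[C@@H](N)[C@@H](O)CO`: 32800 nM
Compound 2 `CCCCCCCCCCCCCC[C@H](N)[C@H](O)CO`: 2660 nM

In a functional assay on A2780 cells (Homo sapiens) for inhibition (a higher number here means a weaker inhibitor, a lower number a stronger inhibitor), compound 2 gives the lower of the two numbers, while compound 1 sits at a higher number, a gap beyond the scatter. Compound 3 `CCCCCCCCCCCCCCCCCC[C@H](N)[C@H](O)CO` has not yet been measured. It differs from compound 2 by butyl in place of hydrogen on a saturated chain carbon, ten or more bonds along the chain from an amine nitrogen. Within the data shown here, no step between measured compounds isolates this change, so the expectation leans on compound 1, whose value of 32800 nM lies well above that of compound 2. A moderate move toward weaker inhibition is expected, a 3.0-fold higher number from compound 2 to compound 3 (0.48 log units; beyond the scatter). Compound 3 is therefore estimated at 8000 nM, within 2000 nM to 32000 nM.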

Compound 3, half-maximal inhibitory concentration: 2710 nM
Compound 3: the middle estimate sits 3.0-fold (0.47 log units) above what was measured, and the stated range covers the measured number.
By their numbers in this assay, from the lowest: compounds 2 and 3 (each within the scatter of the next); then compound 1.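

In this assay, butyl in place of hydrogen on a saturated chain carbon, ten or more bonds along the chain from an amine nitrogen, gives a 1.0-fold higher number from compound 2 to compound 3 (0.01 log units; within the scatter), so this added length does not separate the two compounds. The large gap follows configuration instead, with a 12-fold lower number from compound 1 to compound 3 (1.08 log units; beyond the scatter), and it arises because nothing but the drawn arrangement changes: the fact that compounds 1 and 3 differ only in the configuration as drawn.

The compounds shown leave open whether a shorter chain or a longer chain would give a similar number. They also leave open how an amide in place of the amine would read.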